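Swapping a cyclobutyl for ethyl on the zebrafish-active urea

The compounds below may be only part of what the source reports. "The series", "measured", "known", "first", "only" and "open" are said of these compounds alone.

Among the compounds with values here, compound 1 `NC(=O)c1c(NC(=O)Nc2ccc(Cl)cc2)sc2c1CCN(CC1CCC1)C2` sits at the higher end of the two numbers known in a functional assay (strain AB) with Danio rerio as the target, read by microscopy, with a stated time of 1 h; on this read-out higher numbers stand for an effect only at larger amounts of compound and lower numbers for an effect already at smaller amounts: compound 1 gives 1360 nM, while its charged relative compound 2 `C[N+]1(CC2CC2)CCc2c(sc(NC(=O)Nc3ccc(Cl)cc3)c2C(N)=O)C1` gives 360 nM, a gap beyond the usual scatter. Compound 3 `CCCN1CCc2c(sc(NC(=O)Nc3ccc(Cl)cc3)c2C(N)=O)C1` differs from compound 1 by ethyl in place of cyclobutyl on a saturated chain carbon bound to an amine nitrogen in a ring. Within the data shown here, no measured pair shows this change, so the expected step of a 1.5-fold higher number from compound 1 to compound 3 (0.17 log units; within the scatter) in this assay is small, at most toward a somewhat higher number and possibly within the scatter. Compound 3 is accordingly estimated at 2000 nM, with a range from 700 nM to 6000 nM.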

Compound 3, half-maximal effective concentration: 3500 nM
Compound 3: the middle estimate sits 1.8-fold (0.24 log units) below what was measured, within the range that was stated.
By their numbers in this assay, from the lowest: compound 2; then compound 1; then compound 3.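

Ethyl in place of cyclobutyl on a saturated chain carbon bound to an amine nitrogen in a ring gives in this assay a 2.6-fold higher number from compound 1 to compound 3 (0.41 log units; beyond the scatter) and so shows that this place is not indifferent to the group it carries. Of the two groups, cyclobutyl goes with the lower number. No measurement shown here offers an explanation for this step.

The compounds shown leave open whether the ring itself or only the larger group goes with the lower number. A longer chain such as pentyl or a cyclopentyl ring at this place would bear on that question.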